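The source may hold more compounds than are shown below. What is called first, only, known or untested is meant among the compounds shown, and "the series" means these compounds.

In a functional assay on PC-3 cells (Homo sapiens) for antiproliferative activity, read by MTT assay, with a stated time of 48 h (a higher number here means a weaker inhibitor, a lower number a stronger inhibitor), compound 3 `CCOC(=O)CN(C)C(=O)c1ccc(C(CC)(CC)c2ccc(OCCC(O)(CC)CC)c(C)c2)n1CC` gives 7140 nM and compound 2 `C=CCN(C)C(=O)c1ccc(C(CC)(CC)c2ccc(OCCC(O)(CC)CC)c(C)c2)n1CC` gives 12800 nM; the step between them, a 1.8-fold lower number from compound 2 to compound 3 (0.25 log units; within the scatter), places these two together. For compound 1 `CCn1c(C(=O)N(CCC#N)CCC#N)ccc1C(CC)(CC)c1ccc(OCCC(O)(CC)CC)c(C)c1` the assay reports only a limit, > 50000 nM.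

Compound 4 `CCn1c(C(=O)N(C)CC(=O)O)ccc1C(CC)(CC)c1ccc(OCCC(O)(CC)CC)c(C)c1` alters compound 3 at one place: hydrogen in place of ethyl on an oxygen next to a carbonyl group, which turns ethoxycarbonyl into carboxy. For the measured compounds named here, no measured step makes this exact change. The nearest evidence is an at least 3.9-fold lower number from compound 1 to compound 2 (0.59 log units; beyond the scatter) and an at least 7.0-fold lower number from compound 1 to compound 3 (0.84 log units; beyond the scatter), which show that groups on this carbonyl carbon can shift the number beyond the scatter. A modest move towards a higher number, meaning a weaker inhibitor, is therefore expected: a 2.5-fold higher number from compound 3 to compound 4 (0.40 log units; beyond the scatter). For compound 4 the estimated value is 18000 nM, with an expected range of 6000 nM to 50000 nM.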

Compound 4, half-maximal inhibitory concentration: 2250 nM
Compound 4: middle estimate off by 8.0-fold (0.90 log units), on the high side, outside the stated range (below it).
By their numbers in this assay, from the lowest: compound 4; then compounds 3 and 2 (each within the scatter of the next). At a limit, above all of these: compound 1.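

Replacing ethyl with hydrogen on this oxygen, which turns ethoxycarbonyl into carboxy, moves the number beyond the scatter in this assay: a 3.2-fold lower number from compound 3 to compound 4 (0.50 log units; beyond the scatter). Carboxy also separates from vinyl at this carbon, a 5.7-fold lower number from compound 2 to compound 4 (0.76 log units; beyond the scatter), whereas ethoxycarbonyl and vinyl stayed within the scatter of each other. The widest gap, an at least 22-fold lower number from compound 1 to compound 4 (1.34 log units; beyond the scatter), gives only a bound and rests on a limit: the limit of > 50000 nM in this assay, at which 1 of the 4 values shown sits.

The compounds shown leave open whether the carboxy group itself is needed, since a primary amide or a hydroxymethyl group in its place is not among them. Going by these compounds, how a longer chain between the amide nitrogen and the carboxy group would read also remains open.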